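The source may hold more compounds than are shown below. What is called first, only, known or untested is meant among the compounds shown, and "the series" means these compounds.

Working notes on the series

Three compounds share a core and differ only in the aryl group on the sulfonamide nitrogen. Compound 1 `O=S(=O)(Nc1ccc(Cl)c(Cl)c1)c1ccc(-c2cnc(C3CC3)o2)cc1` carries a 3,4-dichlorophenyl there. In a functional assay on cells (leukaemia cell line, Homo sapiens) for inhibition, read by sulforhodamine B assay, with a stated time of 48 h (on this read-out higher numbers stand for lower toxicity in this test and lower numbers for higher toxicity in this test), compound 1 reaches only the limit > 100000 nM and gives no number. Compound 2 `O=S(=O)(Nc1ccc(F)c(Cl)c1)c1ccc(-c2cnc(C3CC3)o2)cc1` carries a 3-chloro-4-fluorophenyl. In this assay compound 2 likewise reaches only the limit > 100000 nM. The change between them is fluoro in place of chloro on an aromatic carbon, and its step is a step that the two limits leave unreadable from compound 1 to compound 2, since both values sit at the limit of > 100000 nM in this assay, at which 2 of the 3 values shown sit.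

Within the data shown here, compound 3 `Cc1cc(Cl)cc(NS(=O)(=O)c2ccc(-c3cnc(C4CC4)o3)cc2)c1` carries a 3-chloro-5-methylphenyl and in this assay gives 84900 nM, the only number in the set. The core difference to compound 1 is 3-chloro-5-methylphenyl in place of 3,4-dichlorophenyl on a sulfonamide nitrogen; the step is an at least 1.1-fold lower number from compound 1 to compound 3 (0.07 log units; that floor lies within the scatter), and from compound 2 it is an at least 1.1-fold lower number from compound 2 to compound 3 (0.07 log units; that floor lies within the scatter). Neither step can be sized beyond its floor.

Compound 4 `Cc1cc(F)cc(NS(=O)(=O)c2ccc(-c3cnc(C4CC4)o3)cc2)c1`, not yet measured, differs from compound 3 by fluoro in place of chloro on an aromatic carbon. This is the same kind of change as from compound 1 to compound 2, but the place differs: there the fluoro entered ortho to a chloro group and para to a large group, here it enters meta to a large group and meta to a methyl group. The earlier step is unreadable, so the expected step of a 1.5-fold higher number from compound 3 to compound 4 (0.19 log units; within the scatter) rests only on compound 3 at 84900 nM. Compound 4 is expected to give about 130000 nM, between 60000 nM and 300000 nM, with a fair chance that only a limit is reported.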

Compound 4, concentration lethal to 50% of the cells: 78100 nM
The estimate for compound 4 lay 1.7-fold (0.22 log units) above the measured number; the range from low to high includes it.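

In this assay, fluoro in place of chloro on an aromatic carbon, here 3-chloro-5-methylphenyl to 3-fluoro-5-methylphenyl, gives one readable step (a 1.1-fold lower number from compound 3 to compound 4 (0.04 log units; within the scatter)), so in this setting the exchange shows no difference beyond the scatter. The same exchange in the 3,4-dichlorophenyl setting cannot be read, because compound 1 and compound 2 each give only a limit and no number: (the limit of > 100000 nM in this assay, at which 2 of the 4 values shown sit). The steps to compound 4 from the two limit compounds (an at least 1.2-fold lower number from compound 2 to compound 4 (0.10 log units; that floor lies within the scatter)) and (an at least 1.2-fold lower number from compound 1 to compound 4 (0.10 log units; that floor lies within the scatter)) are floors that do not size those differences, so the series shows one readable instance of the exchange and cannot show whether it carries over from one aryl setting to another.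

The aryl groups shown carry only chloro, fluoro and methyl, so what an amine, a carboxylic acid or a methoxy group would give on that ring stays open. All the compounds also keep the shared core and appear in this assay alone, which leaves open how the exchange reads on a different core or in another test.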